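A group exchange at a cytotoxicity limit

This account rests on a few compounds, and the source may have more. Where it says the series, first, only, none or still open, it means among the compounds named here.

In an ADME assay on HEK-293T cells (Homo sapiens) for cytotoxicity, read by CCK-8 assay, with a stated time of 48 h (a higher number here means a weaker inhibitor, a lower number a stronger inhibitor), compound 1 `COc1ccc(Oc2ccccc2-c2ccsc2S(=O)(=O)N2CCN(C(=S)Nc3ccc([N+](=O)[O-])cc3)CC2)cc1OC` stands only at a limit, > 20000 nM. Compound 2 `COc1ccc(Oc2ccc([N+](=O)[O-])cc2-c2ccsc2S(=O)(=O)N2CCN(C(=S)Nc3ccc([N+](=O)[O-])cc3)CC2)cc1OC` also gives only a limit, > 50000 nM. Compound 3 `O=[N+]([O-])c1ccc(NC(=S)NCCNS(=O)(=O)c2ccc(-c3ccccc3O[C@H]3CC[C@H](O)CC3)s2)cc1` gives a number, 10500 nM. Compound 4 `COc1ccc(Oc2ccccc2-c2ccsc2S(=O)(=O)N2CCN(C(=O)Nc3ccc(F)cc3)CC2)cc1OC` differs from compound 1 in one place: a group of 10 heavy atoms (7 carbon, 1 nitrogen, 1 oxygen, 1 fluorine; one six-membered aromatic ring of carbon only) in place of a group of 12 heavy atoms (7 carbon, 2 nitrogen, 2 oxygen, 1 sulfur; one six-membered aromatic ring of carbon only), on an amine nitrogen in a ring. There, (4-fluorophenyl)carbamoyl enters on an amine nitrogen in a ring. Going by the values given here, the one measured step, a step that the two limits leave unreadable from compound 1 to compound 2, is a nitro in place of hydrogen on an aromatic carbon, a different change, and it offers no size to carry over. No change beyond the scatter can therefore be expected in this assay, and the expected step is a step that the limit leaves unreadable from compound 1 to compound 4. Compound 4 is estimated at 30000 nM, with an expected range of 9000 nM to 80000 nM.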

Compound 4, half-maximal inhibitory concentration: > 50000 nM
Compound 4: only a limit was reported (the forecaster's own chance of this, stated with the estimate: 60%); at least 1.6-fold (0.22 log units) between middle value and limit.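

In this assay compound 1 and compound 4 both give only limits, and the step between them cannot be read. The compounds shown leave open whether exchanging the group on the ring nitrogen changes cytotoxicity at all.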